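The compounds below may be only part of what the source reports. "The series", "measured", "known", "first", "only" and "open" are said of these compounds alone.

Compound 1 `CCOC(=O)c1c(-c2cccc(-c3ccccc3)c2)[nH]c2cc(OC)ccc2c1=O` carries a phenyl on an aromatic carbon of its shared core. In an ADME assay on HEK293 cells (Homo sapiens) for cytotoxicity, read by luminescence, with a stated time of 72 h (a lower number here means that less compound is needed, a higher number that more compound is needed for the effect), compound 1 gives > 22000 nM, which is a limit of the assay and not a number. Compound 2 `CCOC(=O)c1c(-c2cccc(OCC)c2)[nH]c2cc(OC)ccc2c1=O` has an ethoxy in place of that phenyl, and in this assay compound 2 gives > 22000 nM, again only a limit. Compound 3 `CCOC(=O)c1c(-c2cccc(C(C)=O)c2)[nH]c2cc(OC)ccc2c1=O` has an acetyl there instead, and in this assay compound 3 gives > 22000 nM, also a limit. The step that the two limits leave unreadable from compound 1 to compound 2, the step that the two limits leave unreadable from compound 1 to compound 3 and the step that the two limits leave unreadable from compound 2 to compound 3 are therefore of unreadable size because of the limit of > 22000 nM in this assay, at which 3 of the 3 values shown sit. Compound 1 thus stands on the limit itself.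

Compound 4 `CCOC(=O)c1c(-c2cccc([N+](=O)[O-])c2)[nH]c2cc(OC)ccc2c1=O` differs from compound 1 by nitro in place of phenyl on an aromatic carbon. The three measured steps bear on this change only in that each exchange of the group on that aromatic carbon left the reading at the limit, so neither a direction nor a size beyond the scatter can be read from them. In this assay compound 4 is expected to sit at the limit as well, the step that the limit leaves unreadable from compound 1 to compound 4 being expected to stay within the scatter. The estimate for compound 4 in this assay is 30000 nM, in the range 15000 nM to 80000 nM.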

Compound 4, half-maximal effective concentration: > 22000 nM
Compound 4: only a limit was reported; the forecaster's own chance of this, stated with the estimate: 80%; the middle value is on the limit's open side.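

For the compounds shown here, compound 4 also gives only a limit of the assay and not a number, so its steps from compound 1, compound 2 and compound 3 cannot be read, and no new step follows, because of this reading: the limit of > 22000 nM in this assay, at which 4 of the 4 values shown sit.

The compounds shown leave open how phenyl, ethoxy, acetyl and nitro on that aromatic carbon compare in this assay.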